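Methoxy for hydroxy on a hydroxyphenyl-bearing core

The source may report more compounds than this note shows. Statements on the series, on what has been measured and on what is new or still open speak of the compounds shown alone.

Measured so far:
compound 1, `O=C1/C(=C\c2ccc(O)cc2)c2ccccc2N1c1c(Cl)cccc1Cl`, 25 ug/mL
compound 2, `Cc1ccc2nc(Cl)c(/C=C3\C(=O)N(c4c(Cl)cccc4Cl)c4ccccc43)cc2c1`, "not determined" (no result reported)

Compound 1 carries a 4-hydroxyphenyl group on the shared core. In a functional assay on HuTu80 cells (Homo sapiens) for cytotoxicity, read by MTT assay, with a stated time of 72 h (on this read-out lower numbers stand for an effect already at smaller amounts and higher numbers for an effect only at larger amounts of compound), compound 1 gives 25 ug/mL. Within the data shown here, it is the only compound here with a number; compound 2 was run but gives "not determined" (no result reported), so nothing can be said of how the two compare.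

Compound 3, `COc1ccc(/C=C2\C(=O)N(c3c(Cl)cccc3Cl)c3ccccc32)cc1`, differs from compound 1 in one place: methyl in place of hydrogen on an oxygen on an aromatic ring. Among the measured compounds shown here, no step between two measured compounds is available to show what such a change does here, and with a single number the expectation must rest on that one value alone.

The expected outcome is a step from compound 1 to compound 3 of no change at the digits printed from compound 1 to compound 3 (within the scatter), which lies within the scatter of repeated measurements, with no direction beyond it.

For compound 3 the estimated result in this assay is 25 ug/mL, with a plausible range from 8 ug/mL to 80 ug/mL, the wider spread reflecting that only compound 1 anchors the estimate.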

Compound 3, concentration for half-maximal effect: > 100 ug/mL
Compound 3 gave a limit, no number; the forecaster's own chance of this, stated with the estimate: 10%; middle value at least 4.0-fold (0.60 log units) from the limit.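

In this assay compound 3 gives > 100 ug/mL, which is a limit of the assay and not a number. Among these compounds, this is the first step seen at this position, and it shows that replacing hydroxy with methoxy on the 4-hydroxyphenyl group is not a neutral change here: the result is an at least 4.0-fold higher number from compound 1 to compound 3 (0.60 log units; beyond the scatter), and that lies beyond the scatter of repeated measurements. Only one end of this step is a number, so its full size remains unknown, and the only evidence available is the limit itself: the limit of > 100 ug/mL in this assay, at which 1 of the 3 values shown sits.

The compounds shown do not reveal whether the step comes from losing the hydrogen on the oxygen or from adding the methyl, and they offer no measured property that would explain it. An amine in place of the hydroxy, or a longer chain such as ethyl on the same oxygen, could help separate these two readings, and a single pair cannot show whether the same step would appear on any other core.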